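A few compounds are considered here, and "the series" means these few. Any claim that something is new, unique, unknown or untested is made for them only; others in the source may bear on it.

In a functional assay on HCT-116 cells (Homo sapiens) for inhibition (a lower number here means a stronger inhibitor, a higher number a weaker inhibitor), compound 1 `CCNC(=O)c1noc(-c2cc(C(C)C)c(O)cc2O)c1-c1cc(COCC(N)=O)no1` gives 97 nM, compound 2 `CCNC(=O)c1noc(-c2cc(C(C)C)c(O)cc2O)c1-c1cc(CNC(C)C)no1` gives 109 nM and compound 3 `C=CNCc1cc(-c2c(C(=O)NCC)noc2-c2cc(C(C)C)c(O)cc2O)on1` gives 121 nM, which leaves compound 3 level with both others within the scatter. Compound 4 `CCNC(=O)c1noc(-c2cc(C(C)C)c(O)cc2O)c1-c1cc(CN(C)C)no1` differs from compound 3 as follows: dimethylamino in place of vinylamino on a saturated chain carbon bound to an aromatic carbon. In short, dimethylamino stands in place of vinylamino on a saturated chain carbon bound to an aromatic carbon. Three measured steps change the group at this place: a 1.1-fold higher number from compound 1 to compound 2 (0.05 log units; within the scatter), a 1.2-fold higher number from compound 1 to compound 3 (0.10 log units; within the scatter) and a 1.1-fold higher number from compound 2 to compound 3 (0.05 log units; within the scatter). Going by the values given here, all three lie within the scatter, although no measured compound carries dimethylamino. No change beyond the scatter is therefore expected in this assay, and the expected step is a 1.1-fold lower number from compound 3 to compound 4 (0.04 log units; within the scatter). For compound 4 the estimated value is 110 nM, with an expected range of 60 nM to 200 nM.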

Compound 4, half-maximal inhibitory concentration: 92 nM
Beside the measured number, compound 4's estimate is 1.2-fold (0.08 log units) above it, and the stated range covers the measured number.
By their numbers in this assay, from the lowest: compounds 4, 1, 2 and 3 (each within the scatter of the next).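

In this assay, dimethylamino on a saturated chain carbon bound to an aromatic carbon stays level with all three earlier groups (a 1.3-fold lower number from compound 3 to compound 4 (0.12 log units; within the scatter)) (a 1.2-fold lower number from compound 2 to compound 4 (0.07 log units; within the scatter)) (a 1.1-fold lower number from compound 1 to compound 4 (0.02 log units; within the scatter)). The hydrogen-bond donor of vinylamino, absent from dimethylamino, is therefore not needed for a value at this level in these compounds. No supporting data are available to explain this tolerance.

Open, as far as these compounds go, is whether a carboxylic acid, a morpholine or a longer chain at this place would also stay level. Also open, from the compounds shown here alone, is whether this flatness holds with the rest of the core changed.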